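From phenyl to 5-bromothiophen-2-yl: compound 3 to compound 4

This account rests on a few compounds, and the source may have more. Where it says the series, first, only, none or still open, it means among the compounds named here.

Measured in an ADME assay on HL-60 cells (Homo sapiens) for cytotoxicity (a higher number here means a weaker inhibitor, a lower number a stronger inhibitor), so far:
- compound 1 `COc1ccc(/C=N/NC(=O)c2ccc(F)cc2)cc1` gives 20 ug/mL
- compound 2 `CN(C)c1ccc(/C=N/NC(=O)c2ccc(F)cc2)cc1` gives > 31.2 ug/mL (a limit, not a number)
- compound 3 `CC(=O)N1N=C(c2ccc(F)cc2)OC1c1ccccc1` gives 31.3 ug/mL

Compound 3 at 31.3 ug/mL and compound 1 at 20 ug/mL lie within the scatter of each other. Compound 2 stands at the limit of > 31.2 ug/mL in this assay, at which 1 of the 3 values shown sits, and gives no number. Compound 4 `CC(=O)N1N=C(c2ccc(F)cc2)OC1c1ccc(Br)s1` differs from compound 3 by 5-bromothiophen-2-yl in place of phenyl on a saturated ring carbon with 5-bromothiophen-2-yl in place of phenyl on a saturated ring carbon. Among the measured compounds shown here, the only measured step is an at least 1.5-fold higher number from compound 1 to compound 2 (0.19 log units; that floor lies within the scatter) and it involves neither group of this change, so it gives no direction. In this assay no step beyond the scatter is therefore expected, and the estimated 1.4-fold lower number from compound 3 to compound 4 (0.15 log units; within the scatter) stays within it. For compound 4 the expected value is 22 ug/mL with an estimated range of 9 ug/mL to 40 ug/mL for now.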

Compound 4, half-maximal inhibitory concentration: 5.9 ug/mL
For compound 4 the middle estimate is 3.7-fold (0.57 log units) above the measured one; measured number below the stated range.
By their numbers in this assay, from the lowest: compound 4; then compounds 1 and 3 (each within the scatter of the next).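

In this assay, among the compounds shown here, the group on the saturated ring carbon clearly matters: 5-bromothiophen-2-yl in place of phenyl gives a 5.3-fold lower number from compound 3 to compound 4 (0.72 log units; beyond the scatter) and is the first step to pass the scatter. For the compounds shown here, the only earlier step lies at another place in a different core, and its floor stays within the scatter. No measurement shown bears on the cause of this step.

Open, going by these compounds, is whether the step follows the bromine or the thiophene ring, and whether plain thiophen-2-yl would keep it. Also open, on these data alone, is how an amine or a carboxylic acid on this phenyl-bearing position's replacement group would read.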